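The source may report more compounds than this note shows. Statements on the series, on what has been measured and on what is new or still open speak of the compounds shown alone.

Measured compounds in a functional assay on CHO cells for agonist activity at Alpha-1D adrenergic receptor (Homo sapiens), read by FLIPR and calcium flux; on this read-out higher numbers stand for an effect only at larger amounts of compound and lower numbers for an effect already at smaller amounts:
compound 1 `Cc1n[nH]cc1-c1cccc2c1CCC2c1ncc[nH]1`, 634 nM
compound 2 `c1cc(-c2ccn[nH]2)c2c(c1)C(c1ncc[nH]1)CC2`, 336 nM
compound 3 `Cn1ccc(-c2cccc3c2CCC3c2ncc[nH]2)n1`, > 10000 nM (a limit of this assay, not a number)

Compound 3 stands at the limit: the limit of > 10000 nM in this assay, at which 1 of the 3 values shown sits. Compound 1 and compound 2 both gave numbers, and the steps of an at least 15-fold higher number from compound 1 to compound 3 (1.19 log units; beyond the scatter) and an at least 29-fold higher number from compound 2 to compound 3 (1.47 log units; beyond the scatter) were large, both beyond the scatter, so compound 3 is the weakest of the three measured. Compound 4 `COc1cccc2c1CCC2c1ncc[nH]1` is to be measured in this assay; the change is methoxy in place of 1-methyl-1H-pyrazol-3-yl on an aromatic carbon. Among the measured compounds shown here, no measured step exchanges this group for methoxy; only the two steps into compound 3 concern the same place, and both moved the number up to the limit. Compound 4 is therefore expected to stay near that limit, an expected step of an at least 2.0-fold lower number from compound 3 to compound 4 (0.30 log units; that floor lies within the scatter), with an estimate of 5000 nM between 800 nM and 30000 nM.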

Compound 4, half-maximal effective concentration: > 10000 nM
Compound 4 was reported as a limit; the forecaster's own chance of this, stated with the estimate: 40%; at least 2.0-fold (0.30 log units) between middle value and limit.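

Methoxy in place of 1H-pyrazol-5-yl gives an at least 29-fold higher number from compound 2 to compound 4 (1.47 log units; beyond the scatter), and methoxy in place of 3-methyl-1H-pyrazol-4-yl gives an at least 15-fold higher number from compound 1 to compound 4 (1.19 log units; beyond the scatter). A small group with no ring therefore ends at the limit just as 1-methyl-1H-pyrazol-3-yl does, and both of these groups carry 0 hydrogen-bond donors. Compound 3 and compound 4 both stand at a limit, so the step between them cannot be read: the limit of > 10000 nM in this assay, at which 2 of the 4 values shown sit.

As far as these compounds go, whether an amine or a hydroxy group at this aromatic carbon would give a measurable number stays open. So does the effect of a plain hydrogen there.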